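A few compounds are considered here, and "the series" means these few. Any claim that something is new, unique, unknown or untested is made for them only; others in the source may bear on it.

Measured compounds:
- compound 1 `COc1cc(/C=N/NC(=O)COc2cccc3ccccc23)cc(OC)c1OC`: 3.26
- compound 2 `O=C(COc1cccc2ccccc12)N/N=C/c1cccc([N+](=O)[O-])c1`: 3.97
- compound 3 `Cc1ccc(/C=N/NC(=O)COc2cccc3ccccc23)cc1`: 4.49

In a physicochemical assay for lipophilicity, measured as octanol-water partition (a lower number here means a more polar compound, a higher number a more lipophilic compound), compound 3 gives the highest of the three numbers. Compound 2 stands nearest to it, with a number lower by more than the scatter, and compound 1 stands furthest, with a number lower by still more. No step between two measured compounds differing in one place is available among these three.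

Compound 4 `O=C(COc1cccc2ccccc12)N/N=C/c1cccc(O)c1` differs from compound 3 as follows: 3-hydroxyphenyl in place of 4-methylphenyl on a carbon with a double bond to nitrogen. Within the data shown here, since no measured pair shows this kind of change, the size of the step can only be expected, not read off. The step from compound 3 to compound 4 in this assay is expected to be downward and beyond the scatter, a number 1.19 log units lower from compound 3 to compound 4 (beyond the scatter). For compound 4 the estimate in this assay is 3.3, within a range from 2.8 to 3.8.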

Compound 4, partition coefficient: 3.73
Estimate against measurement, compound 4: 0.43 log units below; the range from low to high includes it.
By their numbers in this assay, from the lowest: compound 1; then compounds 4 and 2 (each within the scatter of the next); then compound 3.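

In this assay, among these compounds, the step of a number 0.76 log units lower from compound 3 to compound 4 (beyond the scatter) is the first reading of a single change on a carbon with a double bond to nitrogen, with 3-hydroxyphenyl in place of 4-methylphenyl. With hydroxy in place of nitro on an aromatic carbon, the step of a number 0.24 log units lower from compound 2 to compound 4 (within the scatter) leaves those two groups not told apart in this measurement. Nothing measured here gives a reason for either step. Still open, on these data alone, is how an amine or a carboxylic acid on that aromatic carbon would read, and whether a longer chain in place of the methyl of compound 3 would shift the number.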